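Nitrooxy esters on a shared core: liver stability notes

The source may report more compounds than this note shows. Statements on the series, on what has been measured and on what is new or still open speak of the compounds shown alone.

Measured so far:
compound 1, `Cc1cc(OC(=O)OCCCCC(CO[N+](=O)[O-])O[N+](=O)[O-])n(-c2ccccc2)n1`: < 0.0167 h
compound 2, `Cc1cc(OC(=O)CCCCCO[N+](=O)[O-])n(-c2ccccc2)n1`: < 0.0167 h

Both compounds were run in an ADME assay on liver (Rattus norvegicus, strain Wistar) for metabolic stability, read by HPLC, tested at 200 uM; a lower number here means that the compound disappears faster, a higher number that the compound lasts longer. For compound 1 the value < 0.0167 h is a limit of the assay, not a number. For compound 2 the value < 0.0167 h is likewise a limit. Among the measured compounds shown here, compound 1 therefore stands at the low edge of what the assay can report, and the only other value known stands at the same edge (the limit of < 0.0167 h in this assay, at which 2 of the 2 values shown sit). Nothing separates the two compounds within the numbers shown.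

Compound 3, `Cc1cc(OC(=O)OCCCCCCO[N+](=O)[O-])n(-c2ccccc2)n1`, has not been measured. It differs from compound 1 by hydrogen in place of nitrooxy on a saturated chain carbon bound to two saturated chain carbons, so that compound 3 keeps a single nitrooxy group on the chain where compound 1 carries two.

For the measured compounds named here, with both known values sitting at the limit (the limit of < 0.0167 h in this assay, at which 2 of the 2 values shown sit), no measured step is available from which to gauge the effect of this change. The expectation for compound 3 is a half-life at or near that same limit. The expected step is a step that the limit leaves unreadable from compound 1 to compound 3, none beyond the scatter. The estimate for compound 3 in this assay is 0.012 h, with a range from 0.004 h to 0.04 h, and a high chance that only a limit is reported again.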

Compound 3, half-life in the liver assay: < 0.0167 h
Compound 3: only a limit was reported; the forecaster's own chance of this, stated with the estimate: 85%; the middle value does not contradict the limit.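

Compound 1 and compound 3 both return only a limit, not a number, in the liver assay, so no step between them can be read: the limit of < 0.0167 h in the liver assay, at which 3 of the 3 values shown sit.

In a physicochemical assay for metabolic stability, read by HPLC (on this read-out lower numbers stand for a shorter-lived compound and higher numbers for a longer-lived compound), compound 1 gives 3.1 h and compound 3 gives 4 h. This is a 1.3-fold higher number from compound 1 to compound 3 (0.11 log units; within the scatter). On these data alone, whether hydrogen in place of nitrooxy changes the half-life in the liver assay at all stays open.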